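Fluoro removal on the aryl triazole in the cytotoxicity assay

The source may hold more compounds than are shown below. What is called first, only, known or untested is meant among the compounds shown, and "the series" means these compounds.

Compound 2 `Cc1ccc(S(=O)(=O)Oc2ccc3c(c2C)[C@H](Cn2cc(-c4ccc(F)cc4)nn2)[C@@]24CC(=O)[C@@](C)(CC[C@@H]32)C4)cc1` sits at the assay limit: in a functional assay on A549 cells (Homo sapiens) for cytotoxicity, read by MTT assay, with a stated time of 4 days (a higher number here means a weaker inhibitor, a lower number a stronger inhibitor), compound 2 gives > 20000 nM, a limit and not a number. Compound 1 `Cc1ccc(S(=O)(=O)Oc2ccc3c(c2C)[C@H](Cn2cc(-c4ccc(C(F)(F)F)cc4)nn2)[C@@]24CC(=O)[C@@](C)(CC[C@@H]32)C4)cc1` likewise gives only a limit, > 20000 nM in this assay. The step that the two limits leave unreadable from compound 1 to compound 2 is therefore unreadable. Compound 3 `Cc1ccc(S(=O)(=O)Oc2ccc3c(c2C)[C@H](Cn2cc(-c4ccccc4)nn2)[C@@]24CC(=O)[C@@](C)(CC[C@@H]32)C4)cc1` differs from compound 2 by hydrogen in place of fluoro on an aromatic carbon. Within the data shown here, no measured step is readable, and the only evidence is the limit of > 20000 nM in this assay, at which 2 of the 2 values shown sit, so another limit is likely. For compound 3 the expected step is a step that the limit leaves unreadable from compound 2 to compound 3, none beyond the scatter. Compound 3 is estimated at 30000 nM in this assay, range 10000 nM to 100000 nM.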

Compound 3, half-maximal inhibitory concentration: > 20000 nM
Compound 3: only a limit was reported; the forecaster's own chance of this, stated with the estimate: 85%; the middle value does not contradict the limit.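

Compound 3 gives > 20000 nM in this assay, a limit and not a number. Among these compounds, no step among compound 1, compound 2 and compound 3 can be read. The compounds shown leave open whether trifluoromethyl, fluoro or hydrogen on this aromatic carbon makes any difference to cytotoxicity.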